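Swapping a bulky amino group for a small one

The compounds below may be only part of what the source reports. "The series", "measured", "known", "first", "only" and "open" are said of these compounds alone.

Compound 2 `O[C@@H]1Cc2ccccc2[C@H]1NC1CCN(CCCc2c[nH]c3ccc(-n4cnnc4)cc23)CC1` was tested in a functional assay on CHO cells for activation of 5-hydroxytryptamine receptor 1D (Homo sapiens), read by GTPgammaS binding (a higher number here means a larger maximal response, a lower number a smaller maximal response), and gives 75%. Within the data shown here, the only companion with a number is compound 1 `OC[C@H](NC1CCN(CCCc2c[nH]c3ccc(-n4ccnc4)cc23)CC1)c1ccccc1`, which in this assay gives 74%; the two numbers lie within the usual scatter of each other, so neither can be called the larger response. The new compound 3 `CC(C)=CCN(C)C1CCN(CCCc2c[nH]c3ccc(-n4cnnc4)cc23)CC1` keeps the shared core of compound 2 and changes one place: methyl(3-methylbut-2-en-1-yl)amino in place of (2-hydroxy-2,3-dihydro-1H-inden-1-yl)amino on a saturated ring carbon. Among the measured compounds shown here, no measured pair shows what such a swap does to the maximal response, so the expectation rests on the two numbers alone. Since both measured compounds reach a similar level, compound 3 is expected to stay near that level, with the step of a number 3 percentage points higher from compound 2 to compound 3 (within the scatter) estimated as small and not clearly beyond the scatter. For compound 3 the estimate in this assay is 78%, in a range from 55% to 100%.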

Compound 3, largest response reached (reported as efficacy), in percent of the reference or control that the assay uses: 115%
For compound 3 the middle estimate is 37 percentage points below the measured one; the measured number lies above the stated range.
By their numbers in this assay, from the lowest: compounds 1 and 2 (each within the scatter of the next); then compound 3.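

In this assay, the group on this saturated ring carbon, three ring bonds from the ring nitrogen, clearly matters for the maximal response: methyl(3-methylbut-2-en-1-yl)amino in place of (2-hydroxy-2,3-dihydro-1H-inden-1-yl)amino gives a number 40 percentage points higher from compound 2 to compound 3 (beyond the scatter), a large step. Among these compounds, the position therefore accepts an open-chain group with no ring and no hydrogen-bond donors, and this change goes with a higher response, something the earlier compounds could not reveal. Nothing available explains why the response rises.

This single swap alters the size, the rings, the hydrogen-bond donors and the double bond together, and the compounds shown do not separate these changes. From the compounds shown here alone, it remains open how a saturated 3-methylbutyl chain or a plain dimethylamino group at this same place would behave.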